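The compounds below may be only part of what the source reports. "The series", "measured", "known", "first", "only" and "open" are said of these compounds alone.

Measured in a functional assay on SH-SY5Y cells (Homo sapiens) for cytotoxicity, read by MTT assay, with stated times of 1 h and 24 h; a higher number here means that more compound is needed for the effect, a lower number that less compound is needed:

- Compound 1 `O=C(CCN1CCCC1)c1cc2ccc(O)cc2oc1=O`: > 100000 nM (a limit)
- Compound 2 `Cc1cc(O)cc2oc(=O)c(C(=O)CCN(C)C)cc12`: 25700 nM
- Compound 3 `Cc1cc(O)cc2oc(=O)c(C(=O)CCN3CCCCC3)cc12`: > 100000 nM (a limit)

Compound 3 has only a limit, > 100000 nM, and no number. That is the limit of > 100000 nM in this assay, at which 2 of the 3 values shown sit. Compound 4 `Cc1cc(O)cc2oc(=O)c(C(=O)CCN3CCCC3)cc12` has not yet been measured in this assay. It differs from compound 3 in one place, with pyrrolidin-1-yl in place of piperidin-1-yl on a saturated chain carbon, two bonds along the chain from a carbonyl carbon.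

Going by the values given here, one measured step bears directly on this change: an at least 3.8-fold higher number from compound 2 to compound 3 (0.59 log units; beyond the scatter). It lies beyond the scatter and replaces dimethylamino with piperidin-1-yl at the same place. Among the compounds with values here, compound 2, the only compound with a number, gives 25700 nM. Compound 1 also carries pyrrolidin-1-yl, and its result of > 100000 nM is a limit. This suggests that compound 4 may stay close to compound 3, so only a modest move towards a lower number is expected, and a second result at the limit is quite possible. The expected change is an at least 1.4-fold lower number from compound 3 to compound 4 (0.15 log units; that floor lies within the scatter). The estimate for compound 4 is 70000 nM, with an expected range from 25000 nM to 200000 nM.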

Compound 4, half-maximal effective concentration: > 100000 nM
Compound 4 was reported as a limit; the forecaster's own chance of this, stated with the estimate: 55%; middle value at least 1.4-fold (0.15 log units) from the limit.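

In this assay, the change from dimethylamino to pyrrolidin-1-yl on a saturated chain carbon, two bonds along the chain from a carbonyl carbon gives an at least 3.8-fold higher number from compound 2 to compound 4 (0.59 log units; beyond the scatter), so the higher number seen with piperidin-1-yl in an at least 3.8-fold higher number from compound 2 to compound 3 (0.59 log units; beyond the scatter) is not confined to that ring and also appears with the five-membered ring. Compound 4 gives > 100000 nM, which is a limit. The steps from compound 3 to compound 4 and from compound 1 to compound 4 cannot be read, so neither the change of ring size nor methyl in place of hydrogen on an aromatic carbon can be given a size, because these compounds sit at the assay's limit: the limit of > 100000 nM in this assay, at which 3 of the 4 values shown sit.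

From the compounds shown here alone, how compound 1, compound 3 and compound 4 rank against one another remains open, since none of them has a number. Also open, going by these compounds, is whether the higher number would hold for diethylamino, morpholine or piperazine at the same place, or for a longer chain carrying these amines.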